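The source may report more compounds than this note shows. Statements on the series, on what has been measured and on what is new or still open speak of the compounds shown alone.

Measured so far:
compound 1, `O=C(Nc1cccc(-n2cc(-c3ccncc3)c(-c3cc(O)cc(Cl)c3)n2)c1)Nc1ccc(Cl)c(C(F)(F)F)c1`, 58%
compound 2, `O=C(Nc1cccc(-n2cc(-c3ccncc3)c(-c3cc(O)cc(Cl)c3)n2)c1)Nc1ccc(Cl)c(Cl)c1`, 57%
compound 3, `COc1cc(Cl)cc(-c2nn(-c3cccc(NC(=O)Nc4cc(C(F)(F)F)cc(C(F)(F)F)c4)c3)cc2-c2ccncc2)c1`, 64%

In a functional assay on A498 cells (Homo sapiens) for inhibition, read by sulforhodamine B assay, with a stated time of 48 h, tested at 0.01 uM (a lower number here means a stronger effect, a higher number a weaker effect of the compound at the concentration tested), compound 3 gives 64%, the highest of the three numbers. Its nearest neighbour is compound 1 with 58%, and compound 2 with 57% lies furthest away, yet both of these gaps fall within the usual scatter, so the three compounds cannot be told apart on these data.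

Compound 4, `COc1cc(Cl)cc(-c2nn(-c3cccc(NC(=O)Nc4cccc(C(F)(F)F)c4)c3)cc2-c2ccncc2)c1`, has not yet been tested. It differs from compound 3 in one place: hydrogen in place of trifluoromethyl on an aromatic carbon.

Among the compounds with values here, only one measured step bears on this change, and only loosely. From compound 1 to compound 2 one group on the same ring was swapped for another, and the result was a number 1 percentage points lower from compound 1 to compound 2 (within the scatter). Within the data shown here, no measured step removes a trifluoromethyl group outright, so the bearing of that step on compound 4 is indirect.

Given that the one related change stayed within the scatter, compound 4 is expected to land close to compound 3, with no step beyond the scatter: the expected step is a number 1 percentage points higher from compound 3 to compound 4 (within the scatter). The estimate for compound 4 is therefore 65%, expected to fall between 52% and 78%.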

Compound 4, a percentage reported as activity, at one concentration (the size of the read-out at that concentration, not a potency): 95%
For compound 4 the middle estimate is 30 percentage points below the measured one; measured number above the stated range.
By their numbers in this assay, from the lowest: compounds 2, 1 and 3 (each within the scatter of the next); then compound 4.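

In this assay the removal of one trifluoromethyl group gives a number 31 percentage points higher from compound 3 to compound 4 (beyond the scatter), so this carbon, meta to a trifluoromethyl group, is a place where a change can move the number well beyond the scatter. Within the data shown here, the only earlier step, a number 1 percentage points lower from compound 1 to compound 2 (within the scatter), put chloro in place of trifluoromethyl and gave no readable change, whereas here hydrogen enters, and the trifluoromethyl group that stays on the ring of compound 4 does not hold the number near that of compound 3. Nothing measured here explains why this one group counts for so much.

A methyl group, a nitrile or an amine on this carbon would show whether trifluoromethyl itself matters or whether almost any group there will do. As far as these compounds go, it also stays open whether the same removal has a similar effect on the core of compound 1, which carries a hydroxy group where compound 3 carries a methoxy group, and whether the step holds at other concentrations.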